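This account rests on a few compounds, and the source may have more. Where it says the series, first, only, none or still open, it means among the compounds named here.

Three compounds have numbers in a functional assay on DU-145 cells (Homo sapiens) for inhibition, read by trypan blue exclusion, with a stated time of 96 h (a higher number here means a weaker inhibitor of growth, a lower number a stronger inhibitor of growth), so far. Compound 1 (`O=C(/C(=C/c1ccc(Br)cc1)S(=O)(=O)Cc1ccc(I)cc1)c1ccc(I)cc1`) gives 20000 nM and compound 3 (`O=C(/C(=C\c1ccc(O)c([N+](=O)[O-])c1)S(=O)(=O)c1ccc(I)cc1)c1ccc(I)cc1`) gives 25000 nM in this test. Compound 2 (`O=C(/C(=C\c1cc(I)c(O)c(I)c1)SCc1ccc(Br)cc1)c1ccc(Br)cc1`) gives 1000 nM and so holds the lowest of the three numbers, with its gaps to both others lying beyond the scatter. For the measured compounds named here, these three compounds differ from one another in more than one place, so no single-change step between measured compounds is available to guide the next one.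

That next one is compound 4 (`O=C(/C(=C\c1cc(Cl)c(O)c(Cl)c1)SCc1ccc(Br)cc1)c1ccc(Br)cc1`), which has not yet been measured. Its difference from compound 2 is 3,5-dichloro-4-hydroxyphenyl in place of 4-hydroxy-3,5-diiodophenyl on a double-bonded chain carbon bound to a double-bonded chain carbon and the rest of the structure is shared. In plain words, 3,5-dichloro-4-hydroxyphenyl stands in place of 4-hydroxy-3,5-diiodophenyl on a double-bonded chain carbon bound to a double-bonded chain carbon.

Going by the values given here, with no measured step for this exchange, the only anchor is compound 2 at 1000 nM in this assay and the expectation is cautious. A modest move toward a higher number is expected, with the estimated change being a 2.0-fold higher number from compound 2 to compound 4 (0.30 log units; within the scatter) and a result within the scatter remaining possible. For compound 4 the estimated value is 2000 nM with an expected range from 500 nM to 9000 nM in this test.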

Compound 4, concentration for 50% growth inhibition: 10000 nM
Beside the measured number, compound 4's estimate is 5.0-fold (0.70 log units) below it; the measured number lies above the stated range.
By their numbers in this assay, from the lowest: compound 2; then compounds 4, 1 and 3 (each within the scatter of the next, the first and the last beyond it).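

In this assay, for the compounds shown here, the exchange gives the first single-change step in this set: a 10-fold higher number from compound 2 to compound 4 (1.00 log units; beyond the scatter). It shows that the place on a double-bonded chain carbon bound to a double-bonded chain carbon is not indifferent to which halogen the ring carries: the heavy-atom, ring, donor and acceptor counts match on both sides, yet replacing the two iodine atoms with two chlorine atoms moves the number beyond the scatter. Nothing measured here gives a reason for this shift.

Going by these compounds, it remains open whether 3,5-dibromo-4-hydroxyphenyl at this same place would give a number closer to that of compound 2 or that of compound 4, and whether a methoxy group in place of the hydroxyl would keep the number of compound 2. On these data alone, it is also open whether the same halogen exchange would produce a step of similar size on a core carrying a sulfonyl group instead of the sulfur of compound 2, as such a core differs from this pair in more than one place.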